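Moving the methoxy group along the benzyl ether

A few compounds are considered here, and "the series" means these few. Any claim that something is new, unique, unknown or untested is made for them only; others in the source may bear on it.

The measured compounds:
- Compound 1, `COc1cccc(OC)c1OCCNCCOc1ccccc1OCc1cccc(Cl)c1`; in an assay on CHO cells for displacement of a labelled ligand from Alpha-1A adrenergic receptor (Homo sapiens) (on this read-out higher numbers stand for weaker inhibition and lower numbers for stronger inhibition), compound 1 gives 0.251 nM.
- Compound 2, `COc1cccc(OC)c1OCCNCCOc1ccccc1OCc1ccc([N+](=O)[O-])cc1`; in this assay compound 2 gives 1.26 nM.
- Compound 3, `COc1ccccc1COc1ccccc1OCCNCCOc1c(OC)cccc1OC`; in this assay compound 3 gives 2 nM.

All three share one core and differ only in the aromatic group attached to the benzyl ether. Compound 3 stands highest of the three numbers. Its nearest neighbour is compound 2, with a 1.6-fold higher number from compound 2 to compound 3 (0.20 log units; within the scatter), a gap that sits within the scatter; its furthest is compound 1, with an 8.0-fold higher number from compound 1 to compound 3 (0.90 log units; beyond the scatter).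

Compound 4, `COc1cccc(COc2ccccc2OCCNCCOc2c(OC)cccc2OC)c1`, keeps every atom of compound 3 but joins them differently: 3-methoxyphenyl in place of 2-methoxyphenyl on a saturated chain carbon bound to an oxygen on an aromatic ring. Going by the values given here, no measured step moves one group from one position to another; the known steps exchange whole groups. Compound 1, which carries a 3-chlorophenyl group, gave the lowest number, and a 5.0-fold higher number from compound 1 to compound 2 (0.70 log units; beyond the scatter) and an 8.0-fold higher number from compound 1 to compound 3 (0.90 log units; beyond the scatter) show that both replacements weakened binding, but whether the group or its placement mattered cannot be told from these compounds. A small step is expected for compound 4, likely within the scatter, perhaps slightly toward a lower number, as a 1.5-fold lower number from compound 3 to compound 4 (0.19 log units; within the scatter).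

Compound 4 is therefore estimated at 1.3 nM, with a range from 0.4 nM to 4 nM.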

Compound 4, inhibition constant: 2 nM
The estimate for compound 4 lay 1.5-fold (0.19 log units) below the measured number; the measured number falls inside the stated range.
By their numbers in this assay, from the lowest: compound 1; then compounds 2, 3 and 4 (each within the scatter of the next).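

Going by these compounds alone, exchanging 2-methoxyphenyl for 3-methoxyphenyl is the first change here that keeps the same atoms and alters only how they are joined, and in this assay it gives no change at the digits printed from compound 3 to compound 4 (within the scatter) at the printed digits, so these two placements of the methoxy group cannot be told apart. Within the data shown here, the step with methoxy in place of chloro on an aromatic carbon is the first to compare these two groups with the placement held constant, and an 8.0-fold higher number from compound 1 to compound 4 (0.90 log units; beyond the scatter) remains beyond the scatter, so the low number of compound 1 does not depend on a difference in placement alone. The comparison with the nitro compound, a 1.6-fold higher number from compound 2 to compound 4 (0.20 log units; within the scatter) within the scatter, likewise gives no separation between 4-nitrophenyl and 3-methoxyphenyl at this position.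

Nothing available here accounts for the gap between chloro and methoxy. The compounds shown also leave open whether chloro keeps its low number as 2-chlorophenyl or 4-chlorophenyl, and whether a bromo or methyl group in the place of chloro in compound 1 would behave like chloro or like methoxy.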